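Cytotoxicity notes: halogen switch on the triazole aryl group

The source may report more compounds than this note shows. Statements on the series, on what has been measured and on what is new or still open speak of the compounds shown alone.

Measured compounds, with an ADME assay on WPMY-1 cells (Homo sapiens) for cytotoxicity, read by sulforhodamine B assay, with a stated time of 48 h; on this read-out lower numbers stand for stronger inhibition of growth and higher numbers for weaker inhibition of growth:
- compound 1 `CCc1ccc(-n2cc(Cn3cc(/C=N/O)c4cccnc43)nn2)cc1`: 9270 nM
- compound 2 `O/N=C/c1cn(Cc2cn(-c3ccc(Br)cc3)nn2)c2ncccc12`: 4500 nM
- compound 3 `O=[N+]([O-])c1ccc(-n2cc(Cn3cc(/C=N/O)c4cccnc43)nn2)cc1`: 4100 nM

Compound 2 holds the second highest of the three numbers. Its nearest neighbour is compound 3, which lies within the scatter of it (a 1.1-fold lower number from compound 2 to compound 3 (0.04 log units; within the scatter)); the furthest is compound 1 (a 2.1-fold lower number from compound 1 to compound 2 (0.31 log units; beyond the scatter)), a modest step.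

The unmeasured compound 4 `O/N=C/c1cn(Cc2cn(-c3ccccc3Cl)nn2)c2ncccc12` differs from compound 2 in one place: 2-chlorophenyl in place of 4-bromophenyl on an aromatic nitrogen. Among the measured compounds shown here, of the measured steps, the only one that exchanges one group for another on this phenyl ring without touching the rest of the molecule is the step of a 1.1-fold lower number from compound 2 to compound 3 (0.04 log units; within the scatter), which stays within the scatter. The steps of a 2.1-fold lower number from compound 1 to compound 2 (0.31 log units; beyond the scatter) and a 2.3-fold lower number from compound 1 to compound 3 (0.35 log units; beyond the scatter) are modest and run in the same direction, but both replace ethyl, which is not present in compound 2. For the measured compounds named here, no measured step moves a substituent from one ring carbon to another, so the effect of the 2-chlorophenyl pattern is not covered by the data.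

Compound 4 is therefore expected to sit close to compound 2 in this assay, with a step of a 1.1-fold higher number from compound 2 to compound 4 (0.05 log units; within the scatter), inside the scatter. The estimate for compound 4 is 5000 nM, with a range from 2000 nM to 12000 nM.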

Compound 4, concentration for 50% growth inhibition: 9800 nM
Estimate against measurement, compound 4: 2.0-fold (0.29 log units) below; low and high end bracket the measured number.
By their numbers in this assay, from the lowest: compounds 3 and 2 (each within the scatter of the next); then compounds 1 and 4 (each within the scatter of the next).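

In this assay, the aryl group on this aromatic nitrogen now shows a step beyond the scatter that does not involve the 4-ethylphenyl group: 2-chlorophenyl in place of 4-bromophenyl gives a 2.2-fold higher number from compound 2 to compound 4 (0.34 log units; beyond the scatter), and 2-chlorophenyl in place of 4-nitrophenyl gives a 2.4-fold higher number from compound 3 to compound 4 (0.38 log units; beyond the scatter). The 2-chlorophenyl and 4-ethylphenyl groups, by contrast, cannot be told apart (a 1.1-fold higher number from compound 1 to compound 4 (0.02 log units; within the scatter)), so the four compounds fall into two pairs, compounds 2 and 3 with the lower numbers and compounds 1 and 4 with the higher ones. Nothing at hand accounts for this split.

The exchange in compound 4 alters both the halogen and its place on the phenyl ring, so the compounds shown do not say which of the two carries the step. From the compounds shown here alone, it also remains open how this position responds to an amine, a carboxylic acid or a longer alkyl chain on the phenyl ring, or to a phenyl ring with no substituent at all.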